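Shortening the side chain: methoxy replacing methoxymethyl

The source may hold more compounds than are shown below. What is called first, only, known or untested is meant among the compounds shown, and "the series" means these compounds.

Measured compounds:
Compound 1 `Nc1ncc(Cc2ccccc2OCc2ccccc2)c(N)n1` gives 9120 nM in an assay for inhibition of Dihydrofolate reductase (Gallus gallus); a higher number here means a weaker inhibitor, a lower number a stronger inhibitor.
Compound 2 `CCCCCCOc1ccccc1Cc1cnc(N)nc1N` gives 7940 nM in this assay.
Compound 3 `COCc1ccccc1Cc1cnc(N)nc1N` gives 39800 nM in this assay.

Compound 3 stands at the weakest end of these three numbers, beyond the scatter from both compound 1 and compound 2. Compound 4 `COc1ccccc1Cc1cnc(N)nc1N` carries a smaller group: methoxy in place of methoxymethyl on an aromatic carbon. Of the measured steps, only a 5.0-fold higher number from compound 2 to compound 3 (0.70 log units; beyond the scatter) touches the same aromatic carbon, and it shows that changing this group can move the number modestly; a 1.1-fold lower number from compound 1 to compound 2 (0.06 log units; within the scatter) shows that the far end of the chain barely matters. Going by the values given here, no step shortens an ether by one carbon, so the direction is uncertain. For compound 4 a step of about a 1.0-fold higher number from compound 3 to compound 4 (0.00 log units; within the scatter) is expected, giving an estimated 40000 nM with a range from 15000 nM to 110000 nM.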

Compound 4, inhibition constant: 28800 nM
For compound 4 the middle estimate is 1.4-fold (0.14 log units) above the measured one; the measured number falls inside the stated range.
By their numbers in this assay, from the lowest: compounds 2 and 1 (each within the scatter of the next); then compounds 4 and 3 (each within the scatter of the next).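

In this assay, methoxy in place of methoxymethyl on this aromatic carbon gives a 1.4-fold lower number from compound 3 to compound 4 (0.14 log units; within the scatter) and so leaves no readable change: these two short groups cannot be told apart here. Removing the pentyl or the phenyl from the end of the longer side chains counts for more, with a 3.6-fold higher number from compound 2 to compound 4 (0.56 log units; beyond the scatter) and a 3.2-fold higher number from compound 1 to compound 4 (0.50 log units; beyond the scatter) as the two steps. Nothing measured here explains why these steps differ in size. Still open, as far as these compounds go, is where along the chain the number starts to fall, as a propoxy or butoxy group might show, and whether an amine or a carboxylic acid at this place would give a stronger inhibitor.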